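The source may report more compounds than this note shows. Statements on the series, on what has been measured and on what is new or still open speak of the compounds shown alone.

Measured compounds in a functional assay on HeLa cells (Homo sapiens) for cytotoxicity, read by sulforhodamine B assay, with a stated time of 48 h; on this read-out lower numbers stand for stronger inhibition and higher numbers for weaker inhibition:
compound 1 `C=CCOc1ccc(F)cc1C(=O)c1cccnc1` — 93000 nM
compound 2 `C=CCOc1ccc(Br)cc1C(=O)c1cccnc1` — 96000 nM
compound 3 `C=CCOc1c(Cl)cccc1C(=O)c1cccnc1` — 100000 nM

Compound 2 sits second highest of the three numbers, but its separation from compound 1 and from compound 3 is within the scatter, so no ranking among the three is warranted. Among the measured compounds shown here, the only single-place step on record is a 1.0-fold higher number from compound 1 to compound 2 (0.01 log units; within the scatter), which concerns a halogen on an aromatic carbon and is itself within the scatter.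

Compound 4 `O=C(c1cccnc1)c1cc(Br)ccc1O` differs from compound 2 as follows: hydrogen in place of allyl on an oxygen on an aromatic ring. For the measured compounds named here, no measured step touches the oxygen substituent, so the record gives no direct guide; the one step present, within the scatter, suggests this series is insensitive to small changes in this assay. The step from compound 2 to compound 4 is therefore expected to be a 1.0-fold higher number from compound 2 to compound 4 (0.02 log units; within the scatter), with compound 4 estimated at 100000 nM (range 40000 nM to 250000 nM).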

Compound 4, half-maximal inhibitory concentration: 29000 nM
Estimate against measurement, compound 4: 3.4-fold (0.54 log units) above, outside the stated range (below it).
By their numbers in this assay, from the lowest: compound 4; then compounds 1, 2 and 3 (each within the scatter of the next).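

In this assay, among the compounds shown here, allyloxy to hydroxy gives a 3.3-fold lower number from compound 2 to compound 4 (0.52 log units; beyond the scatter), the only step beyond the scatter. The substituent on this oxygen therefore moves the read-out, whereas the halogen exchange on the aromatic carbon did not. No measurement at hand accounts for this step.

From the compounds shown here alone, whether the free hydroxy matters, or only the loss of allyl, stays open; a methoxy or a longer ether chain on this oxygen would separate the two. Going by these compounds, whether the step holds on the cores of compound 1 and compound 3 also stays open.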